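The compounds below may be only part of what the source reports. "The series", "measured", "known", "first", "only" and "open" are said of these compounds alone.

Measured in a functional assay on MOLT-4 cells (Homo sapiens) for inhibition, read by MTT assay, with a stated time of 4 days; on this read-out higher numbers stand for weaker inhibition and lower numbers for stronger inhibition:
- compound 1 `COc1cc(NC(C)CCCNC(=O)NNC(=O)Nc2ccc(Cl)c(C(F)(F)F)c2)c2ncccc2c1`: 19000 nM
- compound 2 `CCOC(=O)NC(c1ccccc1)c1ccc(Cl)cc1`: > 250000 nM, a limit of the assay and not a number
- compound 3 `COc1cc(NC(C)CCCNC(=O)NNC(=O)NCCNC(c2ccccc2)(c2ccccc2)c2ccccc2)c2ncccc2c1`: 8000 nM

Compound 1 has the higher of the two actual numbers, so it is the weaker inhibitor of the pair, and its gap to compound 3 lies beyond the usual scatter. Compound 2 cannot be ranked in the same way, since it has only a limit.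

Compound 4 `COc1cc(NC(C)CCCNC(=O)NNC(=O)NCCCO)c2ncccc2c1` keeps the core of compound 1 but carries 3-hydroxypropyl in place of 4-chloro-3-(trifluoromethyl)phenyl on an amide-type nitrogen. Among the measured compounds shown here, no measured pair shows this change directly, so any forecast is uncertain. For the measured compounds named here, the only measured compounds with this shared core both keep aromatic rings of carbon at this place: compound 1 at 19000 nM and compound 3 at 8000 nM. Compound 4 loses that ring, so a moderate move towards weaker inhibition seems more likely than a gain. The expected change is a 2.9-fold higher number from compound 1 to compound 4 (0.46 log units; beyond the scatter), although a result within the scatter of compound 1 remains possible. For compound 4 the estimated value in this assay is 55000 nM, with an expected range from 15000 nM to 200000 nM.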

Compound 4, half-maximal inhibitory concentration: > 250000 nM
Compound 4 gave a limit, no number; the forecaster's own chance of this, stated with the estimate: 25%; middle value at least 4.5-fold (0.65 log units) away from the limit.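

In this assay, putting 3-hydroxypropyl in place of 4-chloro-3-(trifluoromethyl)phenyl on this amide-type nitrogen gives an at least 13-fold higher number from compound 1 to compound 4 (1.11 log units; beyond the scatter), so inhibition depends strongly on the group carried at this place. Compound 4 has a limit of the assay and not a number, so that step gives only a minimum size: the limit of > 250000 nM in this assay, at which 2 of the 4 values shown sit. Among the compounds sharing this core, compound 1 and compound 3 both keep aromatic rings of carbon at this place and both give numbers, whereas compound 4, the only one without such a ring here, does not.

The step cannot show which part of the change matters most, since the ring, the chlorine and the trifluoromethyl group all leave together while a hydroxyl group arrives on a chain. A plain phenyl ring with neither chlorine nor trifluoromethyl, or a plain propyl chain with no hydroxyl, would help to separate these parts, and the compounds shown give no reading for either group.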